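The compounds below may be only part of what the source reports. "The series", "measured", "known", "first", "only" and "open" are said of these compounds alone.

Measured so far in an assay on isolated protein for inhibition of ubiquitin carboxyl-terminal hydrolase 7 (Homo sapiens), read by fluorescence, with stated times of 30 min and 1 h; a lower number here means a stronger inhibitor, a higher number a weaker inhibitor:
compound 1 `O=C1CCC(=O)N1Cc1cc2nccc(-c3cc(Cl)cc4c3O[C@@H](c3onc5c3CNCC5)C4)c2s1`: 0.38 nM
compound 2 `O=C([C@H]1Cc2cc(Cl)cc(-c3ccnc4ccsc34)c2O1)N1CCNCC1`: 90 nM
compound 3 `Cc1cc(Cl)cc(-c2ccnc3cc(CN4C(=O)C5CC5C4=O)sc23)c1C[C@@H]1CNCCO1`: 0.16 nM

Compound 2 stands at the highest number of the three; compound 1 is nearest, and the gap between them is beyond the scatter, while compound 3 lies furthest from compound 2, also beyond the scatter. Compound 2 is thus the weakest inhibitor of the set, with compound 1 and compound 3 both far stronger.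

The next compound, compound 4 `O=C([C@H]1Cc2cc(Cl)cc(-c3ccnc4cc(Cn5cnccc5=O)sc34)c2O1)N1CCNCC1`, keeps the whole of compound 2 and differs in one place: a group of 8 heavy atoms (5 carbon, 2 nitrogen, 1 oxygen; one six-membered aromatic ring with 2 hetero atoms) in place of a hydrogen atom, on an aromatic carbon. Among the compounds with values here, no step between measured compounds isolates this change, so the expectation can only lean on what compounds 1 and 3 show, both of which carry an additional methylene-linked ring on the shared core and both of which sit far below compound 2. On that basis a large step downward is expected from compound 2 to compound 4, an 18-fold lower number from compound 2 to compound 4 (1.26 log units; beyond the scatter), though its exact size is open, since compounds 1 and 3 differ from compound 2 in other places as well. Compound 4 is therefore estimated at 5 nM, within a range of 1 nM to 30 nM.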

Compound 4, half-maximal inhibitory concentration: 27 nM
The estimate for compound 4 lay 5.4-fold (0.73 log units) below the measured number; measured number inside the range.
By their numbers in this assay, from the lowest: compound 3; then compound 1; then compound 4; then compound 2.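

In this assay, within the data shown here, the aromatic carbon of the five-membered aromatic ring with 1 sulfur, next to the ring sulfur, carries a group of 8 heavy atoms containing one six-membered aromatic ring with 2 hetero atoms in place of a hydrogen atom, giving a 3.3-fold lower number from compound 2 to compound 4 (0.52 log units; beyond the scatter) as the only single-place step. Among these compounds, the position therefore bears this large group without any loss of inhibition, something the earlier compounds could not show because no pair among them differed in one place. The gain is modest, though beyond the scatter. No supporting measurement bears on the origin of this step.

A single step at this carbon leaves open how much depends on the six-membered aromatic ring itself and how much on simply filling the position. Also open, as far as these compounds go, is whether a small methyl group, an aminomethyl group, a carboxylic acid or a longer chain at the same carbon would move the number in the same direction, or further.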